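The source may hold more compounds than are shown below. What is called first, only, known or untested is meant among the compounds shown, and "the series" means these compounds.

Measured compounds:
- compound 1 `Cc1cc(C(=O)O)c(C)n1-c1cccc(Cl)c1` — 430 nM
- compound 2 `Cc1cc(C(=O)O)c(C)n1-c1ccc(Cl)cc1` — 860 nM

Of the compounds shown here, two built on the same core have been measured in an assay on cells for inhibition of Palmitoleoyl-protein carboxylesterase NOTUM variant C330S (Homo sapiens), read by fluorescence, with a stated time of 40 min; a higher number here means a weaker inhibitor, a lower number a stronger inhibitor. Compound 1 `Cc1cc(C(=O)O)c(C)n1-c1cccc(Cl)c1` gives 430 nM in this assay, and compound 2 `Cc1cc(C(=O)O)c(C)n1-c1ccc(Cl)cc1` gives 860 nM. Of the two numbers, that of compound 2 is the higher, but the gap between compound 2 and compound 1 lies within the usual scatter of this assay, so the two cannot be told apart on the evidence at hand.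

The next compound, compound 3 `Cc1cc(C(=O)O)c(C)n1-c1ccc(Cl)c(Cl)c1`, has not yet been measured. It differs from compound 2 in one place: chloro in place of hydrogen on an aromatic carbon. The new chloro sits on an aromatic carbon of a six-membered aromatic ring of carbon only, ortho to a chloro group and meta to a large group.

Among the compounds with values here, no step between measured compounds reproduces this change, so there is no measured guide to its size. Within the data shown here, compound 3 carries a chloro at the place where compound 1 has its own chloro, and compound 1 gives 430 nM, which is the lower of the two known numbers. The expectation for compound 3 is therefore a modest step toward a lower number, a 2.2-fold lower number from compound 2 to compound 3 (0.33 log units; beyond the scatter), rather than one beyond the scatter in the other direction. Compound 3 is estimated at 400 nM in this assay, with a range from 150 nM to 1200 nM.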

Compound 3, half-maximal inhibitory concentration: 270 nM
Estimate against measurement, compound 3: 1.5-fold (0.17 log units) above; the range from low to high includes it.
By their numbers in this assay, from the lowest: compounds 3, 1 and 2 (each within the scatter of the next, the first and the last beyond it).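

In this assay, within the data shown here, placing a chloro in place of hydrogen on an aromatic carbon, ortho to a chloro group and meta to a large group, gives a 3.2-fold lower number from compound 2 to compound 3 (0.50 log units; beyond the scatter) and so provides the first measured step beyond the scatter on this core. Among these compounds, the same kind of change, seen from compound 1, gives a 1.6-fold lower number from compound 1 to compound 3 (0.20 log units; within the scatter) and leaves compound 1 and compound 3 indistinguishable, so the two chloro groups of compound 3 offer no measurable gain over the single chloro of compound 1, while they do separate compound 3 from compound 2. Nothing measured here accounts for either step, so the result stands as an observation without an explanation.

Going by these compounds, whether another group at this place, such as fluoro, methyl, methoxy or a nitrile, would give a step of similar size remains open, as does whether the step would persist without the chloro already on the ring. Also open, on these data alone, is how the two-chloro pattern would fare if the carboxylic acid of the shared core gave way to an amide or an ester.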